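A few compounds are considered here, and "the series" means these few. Any claim that something is new, unique, unknown or untested is made for them only; others in the source may bear on it.

Of the compounds shown here, three sharing one core have been measured in an assay on cells for displacement of a labelled ligand from prostaglandin D2 receptor 2 (Homo sapiens), read by scintillation counting, with a stated time of 60 min; a higher number here means a weaker inhibitor, a lower number a stronger inhibitor. Compound 1 `O=C(O)CCC(=O)N(C1CC1)[C@H]1c2ccccc2N(C(=O)c2cccc(OC(F)(F)F)c2)[C@H]2CC[C@H]21` gives 5 nM, compound 3 `O=C(O)CCC(=O)N(C1CC1)[C@H]1c2ccccc2N(C(=O)c2cccc(F)c2)[C@H]2CC[C@H]21` gives 8.1 nM, and compound 2 `O=C(O)COC(=O)N(C1CC1)[C@H]1c2ccccc2N(C(=O)c2cccc(F)c2)[C@H]2CC[C@H]21` gives 4.1 nM, the lowest of the three numbers, though both others lie within the usual scatter of it: compound 1 sits nearest, compound 3 furthest, with a 2.0-fold higher number from compound 2 to compound 3 (0.30 log units; within the scatter). Compound 4 `O=C(O)COC(=O)N(C1CC1)[C@H]1c2ccccc2N(C(=O)c2ccc(OC(F)(F)F)cc2)[C@H]2CC[C@H]21` differs from compound 2 by 4-(trifluoromethoxy)phenyl in place of 3-fluorophenyl on a carbonyl carbon. Of the measured steps only a 1.6-fold higher number from compound 1 to compound 3 (0.21 log units; within the scatter) bears on this change, since it exchanges the same two substituents, and it stayed within the scatter. The observer therefore expects for compound 4 a number close to that of compound 2, as a 1.0-fold lower number from compound 2 to compound 4 (0.01 log units; within the scatter), with no step beyond the scatter in either direction. The estimate for compound 4 is 4 nM, ranging from 1.5 nM to 12 nM.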

Compound 4, inhibition constant: 2.5 nM
Beside the measured number, compound 4's estimate is 1.6-fold (0.20 log units) above it, and the stated range covers the measured number.
By their numbers in this assay, from the lowest: compounds 4, 2, 1 and 3 (each within the scatter of the next, the first and the last beyond it).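

In this assay, a 1.6-fold lower number from compound 2 to compound 4 (0.21 log units; within the scatter) shows that this carbonyl carbon, on the amide-type nitrogen in a ring, accepts 4-(trifluoromethoxy)phenyl with its 11 heavy atoms in place of 3-fluorophenyl with its 7, without a step beyond the scatter. For the compounds shown here, this is also the first reading of that group alongside the carboxymethoxy side chain. Nothing available gives a reason for this outcome.

As far as these compounds go, it remains open whether the group would read alike with the 2-carboxyethyl chain, and whether an amine or a nitrile on this phenyl ring would be accepted equally.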